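A few compounds are considered here, and "the series" means these few. Any claim that something is new, unique, unknown or untested is made for them only; others in the source may bear on it.

Measured so far:
Compound 1 `COc1cc2c(Oc3ccc(NC(=O)c4nn(-c5cccc(F)c5)c(=O)c5ccccc45)cc3F)ccnc2cc1OCCCN1CCC(C)CC1`: in a functional assay on NCI-H460 cells (Homo sapiens) for cytotoxicity, read by MTT assay, with a stated time of 72 h (on this read-out lower numbers stand for stronger inhibition and higher numbers for weaker inhibition), compound 1 gives 190 nM.
Compound 2 `COc1cc2c(Oc3ccc(NC(=O)c4nn(-c5ccccc5Br)c(=O)c5ccccc45)cc3F)ccnc2cc1OCCCN1CCC(C)CC1`: in this assay compound 2 gives 390 nM.

Within the data shown here, compound 2 holds the higher of the two numbers; its only neighbour is compound 1, and the single measured step, a 2.1-fold higher number from compound 1 to compound 2 (0.31 log units; beyond the scatter), is a modest shift that lies beyond the scatter. Compound 3 `COc1cc2c(Oc3ccc(NC(=O)c4nn(-c5ccc([N+](=O)[O-])cc5)c(=O)c5ccccc45)cc3F)ccnc2cc1OCCCN1CCC(C)CC1` differs from compound 2 by 4-nitrophenyl in place of 2-bromophenyl on an aromatic nitrogen. Among the measured compounds shown here, no measured step bears directly on this exchange: the one step available swaps 3-fluorophenyl for 2-bromophenyl and carries no information on 4-nitrophenyl, so there is no ground for a directional call. The expected step is therefore a 1.3-fold lower number from compound 2 to compound 3 (0.11 log units; within the scatter), which is to say nothing clearly beyond the scatter, with a wide band of uncertainty around it. For compound 3 the estimate in this assay is 300 nM, expected to fall between 120 nM and 800 nM.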

Compound 3, half-maximal inhibitory concentration: 1340 nM
For compound 3 the middle estimate is 4.5-fold (0.65 log units) below the measured one, and the stated range ends below it.
By their numbers in this assay, from the lowest: compound 1; then compound 2; then compound 3.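

In this assay, the aryl group on the aromatic nitrogen spans a wider range than the first pair showed: 4-nitrophenyl in place of 2-bromophenyl gives a 3.4-fold higher number from compound 2 to compound 3 (0.54 log units; beyond the scatter), and 4-nitrophenyl in place of 3-fluorophenyl gives a 7.1-fold higher number from compound 1 to compound 3 (0.85 log units; beyond the scatter). Compound 3 is therefore the weakest of the three, and this position is sensitive to the choice of aryl group, with 4-nitrophenyl the least favourable of those shown. Nothing available on these compounds accounts for this order.

Each of the three rings differs in both its substituent and where that substituent sits, so the contributions of the two remain inseparable. Going by these compounds, how an unsubstituted phenyl, or a phenyl carrying an amine or a carboxylic acid, would fall relative to these three remains open.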